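Thiophene for dimethylaminophenyl in the nitro-bearing ketone

The source may report more compounds than this note shows. Statements on the series, on what has been measured and on what is new or still open speak of the compounds shown alone.

Compound 1 `Cc1ccsc1/C=C(/SCc1ccc(Cl)cc1)C(=O)c1ccc(Cl)cc1` gives 50000 nM in a functional assay on DU-145 cells (Homo sapiens) for inhibition, read by trypan blue exclusion, with a stated time of 96 h; a higher number here means a weaker inhibitor of growth, a lower number a stronger inhibitor of growth. Compound 2 `CN(C)c1ccc(/C=C(/SCc2ccc(Cl)cc2)C(=O)c2ccc(Cl)cc2)cc1` reaches only the limit of this assay, > 100000 nM. Compound 3 `CN(C)c1ccc(/C=C(/SCc2ccc(Cl)cc2)C(=O)c2ccc([N+](=O)[O-])cc2)cc1` likewise sits at a limit, > 100000 nM. The change 3-methylthiophen-2-yl in place of 4-(dimethylamino)phenyl on a double-bonded chain carbon bound to a double-bonded chain carbon makes a step of an at least 2.0-fold lower number from compound 2 to compound 1 (0.30 log units; that floor lies within the scatter). The change nitro in place of chloro on an aromatic carbon gives a step that the two limits leave unreadable from compound 2 to compound 3. Compound 4 `Cc1ccsc1/C=C(/SCc1ccc(Cl)cc1)C(=O)c1ccc([N+](=O)[O-])cc1` is not yet measured; it differs from compound 3 by 3-methylthiophen-2-yl in place of 4-(dimethylamino)phenyl on a double-bonded chain carbon bound to a double-bonded chain carbon, the same change as from compound 2 to compound 1, at the same place. For compound 4 a step of an at least 1.4-fold lower number from compound 3 to compound 4 (0.15 log units; that floor lies within the scatter) is expected, resting on the earlier step of an at least 2.0-fold lower number from compound 2 to compound 1 (0.30 log units; that floor lies within the scatter) and on the position of compound 3 at the limit of > 100000 nM in this assay, at which 2 of the 3 values shown sit. Compound 4 is estimated at 70000 nM, within 30000 nM and 150000 nM, with a fair chance that only a limit is returned.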

Compound 4, concentration for 50% growth inhibition: > 100000 nM
Compound 4 ended at the assay's limit; the forecaster's own chance of this, stated with the estimate: 45%; at least 1.4-fold (0.15 log units) between middle value and limit.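

In this assay compound 4 returns only a limit, > 100000 nM. The change to 3-methylthiophen-2-yl in place of 4-(dimethylamino)phenyl, seen as an at least 2.0-fold lower number from compound 2 to compound 1 (0.30 log units; that floor lies within the scatter), is neither confirmed nor refuted on the nitro-bearing core, and steps between two limits cannot be read: the limit of > 100000 nM in this assay, at which 3 of the 4 values shown sit. Nitro in place of chloro gives an at least 2.0-fold higher number from compound 1 to compound 4 (0.30 log units; that floor lies within the scatter), so no effect of that change is established on the core of compound 1.

Only compound 1 gives a number rather than a limit, so a single measured point carries the comparison. From the compounds shown here alone, whether an amine or a carboxylic acid in place of its chloro would shift compound 1 from 50000 nM stays open.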